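A few compounds are considered here, and "the series" means these few. Any claim that something is new, unique, unknown or untested is made for them only; others in the source may bear on it.

Three ureas built on the shared core of compound 1 `Nc1n[nH]c2cccc(-c3cccc(NC(=O)Nc4ccc(Cl)cc4Cl)c3)c12` have been measured in a functional assay on SMMC-7721 cells (Homo sapiens) for inhibition, read by MTT assay, with a stated time of 48 h; a higher number here means a weaker inhibitor, a lower number a stronger inhibitor. Compound 1 gives 1900 nM, the highest of the three numbers. Within the data shown here, compound 3 `Nc1n[nH]c2cccc(-c3cccc(NC(=O)Nc4ccc(Cl)c(C(F)(F)F)c4)c3)c12`, which also carries a trifluoromethyl group on its terminal phenyl, gives 1150 nM; no single-point step is drawn between compound 1 and compound 3, and their two values lie within the scatter of each other. Among the measured compounds shown here, compound 2 `CC(C)c1cccc(NC(=O)Nc2cccc(-c3cccc4[nH]nc(N)c34)c2)c1` gives 280 nM, so the step of a 6.8-fold lower number from compound 1 to compound 2 (0.83 log units; beyond the scatter) is the only change so far that reaches beyond the scatter.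

Compound 4 `Nc1n[nH]c2cccc(-c3cccc(NC(=O)Nc4cccc(C(F)(F)F)c4)c3)c12` differs from compound 1 in one place: 3-(trifluoromethyl)phenyl in place of 2,4-dichlorophenyl on an amide-type nitrogen. The step that bears on it is a 6.8-fold lower number from compound 1 to compound 2 (0.83 log units; beyond the scatter), a modest gain from replacing the same 2,4-dichlorophenyl group, while compound 3 shows that a trifluoromethyl-bearing phenyl gives 1150 nM. Compound 4 is therefore expected to show a modest move to a lower number, a 2.9-fold lower number from compound 1 to compound 4 (0.47 log units; beyond the scatter). The estimate for compound 4 is 650 nM, expected to fall between 250 nM and 1600 nM.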

Compound 4, half-maximal inhibitory concentration: 1410 nM
Compound 4: the middle estimate sits 2.2-fold (0.34 log units) below what was measured, within the range that was stated.
By their numbers in this assay, from the lowest: compound 2; then compounds 3, 4 and 1 (each within the scatter of the next).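

In this assay, 3-(trifluoromethyl)phenyl in place of 2,4-dichlorophenyl on the amide-type nitrogen gives a 1.3-fold lower number from compound 1 to compound 4 (0.13 log units; within the scatter) and so does not repeat the gain seen with 3-isopropylphenyl at this place. Hydrogen in place of chloro on an aromatic carbon gives a 1.2-fold higher number from compound 3 to compound 4 (0.09 log units; within the scatter) and leaves no readable effect of that chloro. Trifluoromethyl in place of isopropyl on an aromatic carbon gives a 5.0-fold higher number from compound 2 to compound 4 (0.70 log units; beyond the scatter) as the one new step beyond the scatter, setting compound 2 apart from compounds 1, 3 and 4, which lie within the scatter of each other.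

No supporting measurement explains this difference between isopropyl and trifluoromethyl. The compounds shown leave open whether a tert-butyl, cyclopropyl or methoxy group on the terminal phenyl would give a number like that of compound 2 or one like that of compound 4.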